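Branched Alkyl Chains on a Cyanoguanidine Core

The source may report more compounds than this note shows. Statements on the series, on what has been measured and on what is new or still open speak of the compounds shown alone.

Three compounds share a cyanoguanidine core carrying a bis(trifluoromethyl)phenyl group, and differ only in the alkyl chain on the double-bonded nitrogen. In a functional assay on Beta-TC3 cells (Rattus norvegicus) with Beta-TC3 (Mus musculus) as the target, using a membrane potential dye (on this read-out higher numbers stand for weaker inhibition and lower numbers for stronger inhibition), compound 1 `CCC/N=C(\NC#N)Nc1cc(C(F)(F)F)cc(C(F)(F)F)c1` gives 19000 nM, compound 2 `CC(C)CC/N=C(\NC#N)Nc1cc(C(F)(F)F)cc(C(F)(F)F)c1` gives 4700 nM, and compound 3 `CC(C)C(C)/N=C(\NC#N)Nc1cc(C(F)(F)F)cc(C(F)(F)F)c1` gives 5500 nM. Compound 3 thus stands second highest of the three numbers: its nearest neighbour is compound 2, from which it is separated only within the scatter (a 1.2-fold higher number from compound 2 to compound 3 (0.07 log units; within the scatter)), while the step of a 3.5-fold lower number from compound 1 to compound 3 (0.54 log units; beyond the scatter) lies beyond the scatter, as does the related step of a 4.0-fold lower number from compound 1 to compound 2 (0.61 log units; beyond the scatter).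

Compound 4 `C[C@H](/N=C(\NC#N)Nc1cc(C(F)(F)F)cc(C(F)(F)F)c1)C(C)(C)C` extends the branching once more: 1,2,2-trimethylpropyl in place of 1,2-dimethylpropyl on a double-bonded nitrogen. For the measured compounds named here, the steps that bear on this change are those from the shorter chain of compound 1 to the branched chains of compound 2 and compound 3, both modest, and the step between the two branched chains, which stayed within the scatter. Since a 1.2-fold higher number from compound 2 to compound 3 (0.07 log units; within the scatter) shows that a change of branching between two chains of similar size had no effect beyond the scatter, no step beyond the scatter is expected for a 1.2-fold lower number from compound 3 to compound 4 (0.09 log units; within the scatter) in this assay. Compound 4 is therefore estimated at 4500 nM, within a range of 1800 nM to 11000 nM.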

Compound 4, half-maximal inhibitory concentration: 12000 nM
The estimate for compound 4 lay 2.7-fold (0.43 log units) below the measured number, outside the stated range (above it).
By their numbers in this assay, from the lowest: compounds 2 and 3 (each within the scatter of the next); then compounds 4 and 1 (each within the scatter of the next).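

In this assay, the 1,2,2-trimethylpropyl chain on the double-bonded nitrogen separates from the 1,2-dimethylpropyl chain by a modest step beyond the scatter (a 2.2-fold higher number from compound 3 to compound 4 (0.34 log units; beyond the scatter)), whereas the change from isopentyl to 1,2-dimethylpropyl had stayed within it (a 1.2-fold higher number from compound 2 to compound 3 (0.07 log units; within the scatter)), so the number at this position does respond to a change among branched chains. For the compounds shown here, the new chain also stands apart from isopentyl (a 2.6-fold higher number from compound 2 to compound 4 (0.41 log units; beyond the scatter)) but not from propyl (a 1.6-fold lower number from compound 1 to compound 4 (0.20 log units; within the scatter), within the scatter), which means that the advantage of compound 2 and compound 3 over compound 1 does not extend to compound 4, the one compound that goes against any reading of more branching as giving lower numbers. Nothing available here accounts for this reversal.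

The compounds shown leave open whether the step belongs to the 1,2,2-trimethylpropyl chain as a whole or depends on its defined stereocentre, which the mirror-image form of compound 4 would address. They also leave open how a longer chain such as hexyl, or a ring such as cyclohexyl, would read on the same nitrogen.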